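Two Chlorines Out, Two Methoxy Groups In

The source may report more compounds than this note shows. Statements on the series, on what has been measured and on what is new or still open speak of the compounds shown alone.

Compound 1 `Cc1oc(-c2c(Cl)cccc2Cl)nc1CN1CCC(C(=O)NCCCN2C[C@H](C)C[C@H](C)C2)CC1` was tested in an ADME assay on microsomes from liver (Rattus norvegicus) for metabolic stability, read by LC-MS, using NADPH, at 37 degrees C (a lower number here means that the compound disappears faster, a higher number that the compound lasts longer), where compound 1 gives 0.0483 h. Among the results reported as numbers this is the lowest of two, but compound 2 `Cc1cccc(Cl)c1-c1nc(CN2CCC(C(=O)NCCCN3CCCC(C)C3)CC2)c(C)o1` gives 0.09 h in this assay, and that gap sits within the usual scatter, so the two compounds cannot be told apart on this footing. Compound 3 `Cc1ccccc1-c1nc(CN2CCC(C(=O)N3CCN(CCN(C)C)CC3)CC2)c(C)o1` is reported in this assay only as a limit, > 0.5 h, and not as a number (the limit of > 0.5 h in this assay, at which 1 of the 3 values shown sits).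

Compound 4 `COc1cccc(OC)c1-c1nc(CN2CCC(C(=O)NCCCN3C[C@H](C)C[C@H](C)C3)CC2)c(C)o1` has not yet been measured. It differs from compound 1 in one place: 2,6-dimethoxyphenyl in place of 2,6-dichlorophenyl on an aromatic carbon. For the measured compounds named here, no pair of measured compounds shows what this change does in this assay, so no direction is known in advance, and nothing among the measured compounds points to a change beyond the scatter. The expected step of a 1.1-fold lower number from compound 1 to compound 4 (0.03 log units; within the scatter) is therefore small. The estimate for compound 4 in this assay is 0.045 h, with a range from 0.015 h to 0.13 h.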

Compound 4, half-life: 0.2 h
Beside the measured number, compound 4's estimate is 4.4-fold (0.65 log units) below it; the measured number lies above the stated range.
By their numbers in this assay, from the lowest: compounds 1 and 2 (each within the scatter of the next); then compound 4. At a limit, above all of these: compound 3.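

Replacing 2,6-dichlorophenyl with 2,6-dimethoxyphenyl on the core of compound 1 gives, in this assay, a 4.1-fold higher number from compound 1 to compound 4 (0.62 log units; beyond the scatter). For the compounds shown here, this is the first pair here that differs in one place, so it is the first direct sign that a single change at this aromatic carbon can move the half-life beyond the scatter, with the rest of the molecule held constant. The compounds shown offer no measured property that explains the step.

This one pair cannot show whether the rise comes from the oxygen atoms, from the larger size of the new group, or from the loss of the chlorines. Also open, on these data alone, are how 2,6-difluorophenyl or 2,6-diethoxyphenyl would read at this position, and whether the same swap holds with a different amine at the far end of the chain.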